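Dithiocarbamate chalcones: trimethoxyphenyl replaced by difluorophenyl

The source may hold more compounds than are shown below. What is called first, only, known or untested is meant among the compounds shown, and "the series" means these compounds.

Measured so far:
- compound 1 `O=C(/C=C/c1cc(F)cc(F)c1)c1ccc(OCCCSC(=S)N2CCCC2)cc1`: 28800 nM
- compound 2 `COc1ccc(/C=C/C(=O)c2ccc(OCCCSC(=S)N3CCN(C)CC3)cc2)cc1`: a limit, > 100000 nM
- compound 3 `COc1cc(/C=C/C(=O)c2ccc(OCCCSC(=S)N3CCN(C)CC3)cc2)cc(OC)c1OC`: 7430 nM

In a functional assay on ECa-109 cells for inhibition, with ECa-109 cell line (Homo sapiens) as the target, read by MTT assay, with a stated time of 72 h (a higher number here means a weaker inhibitor, a lower number a stronger inhibitor), compound 3 gives 7430 nM, the lowest number among the two numbers in hand; compound 1 sits at 28800 nM, a higher number beyond the scatter. For compound 2 only a limit is reported, > 100000 nM. Among the compounds with values here, the one step within the measured set, an at least 13-fold lower number from compound 2 to compound 3 (1.12 log units; beyond the scatter), shows how much the aryl group on the double-bonded chain carbon matters.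

Compound 4 `CN1CCN(C(=S)SCCCOc2ccc(C(=O)/C=C/c3cc(F)cc(F)c3)cc2)CC1` differs from compound 3 by 3,5-difluorophenyl in place of 3,4,5-trimethoxyphenyl on a double-bonded chain carbon bound to a double-bonded chain carbon. Within the data shown here, no measured step covers this exact exchange. The step from compound 2 to compound 3 shows that removing two of the three methoxy groups costs a large amount, so giving up all three acceptors for two fluorines is expected to move the number upward as well. Compound 1, which carries the same 3,5-difluorophenyl on a different dithiocarbamate, gives 28800 nM and points to the same region. Compound 4 is therefore expected to show a 4.7-fold higher number from compound 3 to compound 4 (0.67 log units; beyond the scatter) and to land near 35000 nM, with a range from 12000 nM to 100000 nM.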

Compound 4, half-maximal inhibitory concentration: 14500 nM
Compound 4: the middle estimate sits 2.4-fold (0.38 log units) above what was measured; low and high end bracket the measured number.
By their numbers in this assay, from the lowest: compounds 3, 4 and 1 (each within the scatter of the next, the first and the last beyond it). At a limit, above all of these: compound 2.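

In this assay, a 2.0-fold higher number from compound 3 to compound 4 (0.29 log units; within the scatter), so at this place on a double-bonded chain carbon bound to a double-bonded chain carbon, 3,5-difluorophenyl can stand in for 3,4,5-trimethoxyphenyl and no methoxy group is needed to stay in this range. The other end of the molecule shows no separation either: a 2.0-fold lower number from compound 1 to compound 4 (0.30 log units; within the scatter), with 4-methylpiperazin-1-yl in place of pyrrolidin-1-yl on the thiocarbonyl carbon. Compound 4 carries no methoxy group yet goes against a simple methoxy count, and the step of an at least 6.8-fold lower number from compound 2 to compound 4 (0.83 log units; beyond the scatter) rests on a limit for compound 2: the limit of > 100000 nM in this assay, at which 1 of the 4 values shown sits.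

From the compounds shown here alone, whether plain phenyl or 4-fluorophenyl at this place would group with compound 4 or with compound 2 stays open. Also open, going by these compounds, is how a morpholin-4-yl on the thiocarbonyl carbon, or a longer chain, would read.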